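A chloro for a carbamoyl on the benzyl ring

The source may report more compounds than this note shows. Statements on the series, on what has been measured and on what is new or still open speak of the compounds shown alone.

Three compounds sharing one core have been run in an assay for inhibition of MAP kinase-interacting serine/threonine-protein kinase 2 (Homo sapiens), read by luminescence and ADP-Glo, with a stated time of 2 h; a higher number here means a weaker inhibitor, a lower number a stronger inhibitor. Compound 1 `O=c1ccc(-c2ccc3cn[nH]c3c2)cn1Cc1cccc(C(F)(F)F)c1` gives 32 nM. Compound 2 `NC(=O)c1ccccc1Cn1cc(-c2ccc3cn[nH]c3c2)ccc1=O` gives 340 nM, the highest of the two numbers reported, and the gap that separates it from compound 1 lies well beyond the scatter. Compound 3 `Cn1ncc2ccc(-c3ccc(=O)n(Cc4ccccc4)c3)cc21` gives only a limit of the assay, > 2000 nM, so its true value is not known; it sits at the limit of > 2000 nM in this assay, at which 1 of the 3 values shown sits.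

Compound 4 `O=c1ccc(-c2ccc3cn[nH]c3c2)cn1Cc1ccccc1Cl` has not yet been tested. It differs from compound 2 in one place: chloro in place of carbamoyl on an aromatic carbon. The group leaving carries one hydrogen-bond donor and one acceptor; the group entering carries neither.

Among the measured compounds shown here, no pair of measured compounds differs in just one place, so the size of this step cannot be read off directly. For the measured compounds named here, the only guide is that compound 1, which also carries a group without donors or acceptors on its benzyl ring, gives 32 nM, a much lower number than compound 2. On that basis compound 4 is expected to move toward a lower number, by an amount estimated as a 2.8-fold lower number from compound 2 to compound 4 (0.45 log units; beyond the scatter). Compound 4 is estimated at 120 nM, with a range from 35 nM to 450 nM.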

Compound 4, half-maximal inhibitory concentration: 78 nM
Beside the measured number, compound 4's estimate is 1.5-fold (0.19 log units) above it; the measured number falls inside the stated range.
By their numbers in this assay, from the lowest: compound 1; then compound 4; then compound 2. At a limit, above all of these: compound 3.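

Among the compounds shown here, this is the first step that changes one place alone, and it isolates the carbamoyl on the aromatic carbon ortho to a large group. In this assay, chloro in place of carbamoyl gives a 4.4-fold lower number from compound 2 to compound 4 (0.64 log units; beyond the scatter), so the number does not depend on keeping the hydrogen-bond donor and acceptor of the carbamoyl at this position, and a single chlorine atom can stand in for the three heavy atoms that leave. The data shown measure the size of this step but offer nothing that explains it, and the one limit among the values has no bearing on this change.

Since the donor, the acceptor and the size of the group all change together in this one step, their separate contributions cannot be told apart. The compounds shown also leave open how a methyl, a methoxy or an amine on this same aromatic carbon would compare with chloro, and whether chloro would give a similar step on another carbon of the benzyl ring.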